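The source may report more compounds than this note shows. Statements on the series, on what has been measured and on what is new or still open speak of the compounds shown alone.

For the measured compounds named here, in a functional assay on MCF7 cells (Homo sapiens) for antiproliferative activity, read by MTT assay, with a stated time of 72 h (on this read-out higher numbers stand for weaker inhibition and lower numbers for stronger inhibition), compound 1 (`CCC1OCc2c(/C=C/C(C)=O)cnc(C)c2O1`) gives 3900 nM and holds the higher of the two numbers so far, while compound 2 (`CCCCC1OCc2c(/C=C/C(C)=O)cnc(C)c2O1`) gives 1300 nM on the same read-out. Compound 3 (`CC(=O)/C=C/c1cnc(C)c2c1COC(C(C)(C)C)O2`) is still unmeasured. It keeps the core of compound 1 with one change (tert-butyl in place of ethyl on a saturated ring carbon), tert-butyl in place of ethyl on a saturated ring carbon. Going by the values given here, only one measured step bears on this, the longer chain at that part of the molecule, with a 3.0-fold lower number from compound 1 to compound 2 (0.48 log units; beyond the scatter) as a modest change beyond the scatter. No branched group has been measured, so a smaller step towards lower numbers is expected, and no real change remains possible. That expected step is a 2.0-fold lower number from compound 1 to compound 3 (0.29 log units; within the scatter) by this estimate. In this assay the estimated value for compound 3 is 2000 nM with an expected range from 800 nM to 5000 nM around it.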

Compound 3, half-maximal inhibitory concentration: 4100 nM
Compound 3: middle estimate off by 2.1-fold (0.31 log units), on the low side; the measured number falls inside the stated range.
By their numbers in this assay, from the lowest: compound 2; then compounds 1 and 3 (each within the scatter of the next).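

In this assay, putting tert-butyl in place of ethyl on this saturated ring carbon gives a 1.1-fold higher number from compound 1 to compound 3 (0.02 log units; within the scatter), which is no real change. Putting tert-butyl in place of butyl gives a 3.2-fold higher number from compound 2 to compound 3 (0.50 log units; beyond the scatter), so the lower number seen with the butyl chain does not carry over to this branched group, and compound 3 goes against any idea that a bigger group here simply brings a lower number. No available evidence explains why these two groups differ at this position.

A less branched group such as isopropyl or isobutyl could show how much branching this position tolerates before the number rises. On these data alone, it also remains open whether a longer chain such as hexyl, or a ring such as cyclohexyl or phenyl, would lower the number further.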